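Fluoro for methyl on the aryl ring: expected lipophilicity

A few compounds are considered here, and "the series" means these few. Any claim that something is new, unique, unknown or untested is made for them only; others in the source may bear on it.

Measured compounds:
Compound 1 `C[C@H]1CC[C@@H]2[C@@H](OC(=O)[C@]23CC(c2ccccc2F)=NO3)[C@]2(C)C(=O)C=C[C@@]12O`: 1.58
Compound 2 `Cc1ccccc1C1=NO[C@]2(C1)C(=O)O[C@@H]1[C@H]2CC[C@H](C)[C@]2(O)C=CC(=O)[C@@]12C`: 1.86
Compound 3 `Cc1ccc(C2=NO[C@]3(C2)C(=O)O[C@@H]2[C@H]3CC[C@H](C)[C@]3(O)C=CC(=O)[C@@]23C)cc1`: 1.86

All three were measured in a physicochemical assay for lipophilicity; a higher number here means a more lipophilic compound, a lower number a more polar compound. They share one core and differ only in the aryl group sitting on the carbon with a double bond to nitrogen. Compound 2 and compound 3 are built from the same atoms joined differently: 4-methylphenyl in place of 2-methylphenyl on a carbon with a double bond to nitrogen. In this assay this gives no change at the digits printed from compound 2 to compound 3 (within the scatter). Compound 1 carries a fluoro where compound 2 carries a methyl: fluoro in place of methyl on an aromatic carbon. That swap gives a number 0.28 log units lower from compound 2 to compound 1 (within the scatter).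

Compound 4 `C[C@H]1CC[C@@H]2[C@@H](OC(=O)[C@]23CC(c2ccc(F)cc2)=NO3)[C@]2(C)C(=O)C=C[C@@]12O` has not yet been measured. It is made from compound 3 by fluoro in place of methyl on an aromatic carbon. Within the data shown here, this is the same kind of change as the one that turns compound 2 into compound 1, but not the same: in compound 1 the fluoro sits ortho to a large group, whereas in compound 4 it sits para to a large group. Among the measured compounds shown here, with only one measured example of a methyl-to-fluoro swap on this ring, the expectation rests on that single step. The step from compound 3 to compound 4 is therefore expected to be a number 0.28 log units lower from compound 3 to compound 4 (within the scatter), mirroring the measured step of a number 0.28 log units lower from compound 2 to compound 1 (within the scatter). On that basis compound 4 is expected to give about 1.58 in this assay, with a likely range from 1.3 to 1.9.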

Compound 4, partition coefficient: 1.58
Compound 4: middle estimate and measured number agree at the digits printed; measured number inside the range.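

In this assay, fluoro in place of methyl gives a number 0.28 log units lower from compound 3 to compound 4 (within the scatter) when it sits para to a large group, a step of the same size as a number 0.28 log units lower from compound 2 to compound 1 (within the scatter) on the same aryl ring, so the two methyl-to-fluoro pairs read alike. This is a repeat at a second place on one shared core, not a transfer to a different core, and each of these steps lies within the scatter, so two matching numbers do not establish a real effect of the swap, let alone one that would hold elsewhere. The remaining steps, a number 0.28 log units lower from compound 2 to compound 4 (within the scatter) and no change at the digits printed from compound 1 to compound 4 (within the scatter), are also within the scatter, so these compounds are not clearly separated in this read-out, and nothing shown here bears on why the steps have this size.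

The compounds shown leave open whether fluoro in place of methyl gives a comparable step on any other core, which would be the real test of carrying this change across the series. They also leave open how this read-out responds to quite different groups on the aryl ring, such as an amine, a carboxylic acid or a longer chain, where a step might stand clear of the scatter.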